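A few compounds are considered here, and "the series" means these few. Any claim that something is new, unique, unknown or untested is made for them only; others in the source may bear on it.

Measured so far:
- compound 1, `CC1(C)Oc2ccc(C(=O)Cc3ccccc3)cc2[C@@H](/N=C(\NC#N)Nc2ccc(Cl)cc2)[C@@H]1O`: 6800 nM
- compound 2, `CC1(C)Oc2ccc(Cc3ccccc3)cc2[C@@H](/N=C(\NC#N)Nc2ccc(Cl)cc2)[C@@H]1O`: 10000 nM
- compound 3, `CC1(C)Oc2ccc(S(=O)(=O)Nc3ccccc3)cc2[C@@H](/N=C(\NC#N)Nc2ccc(Cl)cc2)[C@@H]1O`: 3300 nM

All three share one core and differ only in the substituent on the aromatic carbon. In a functional assay (aorta) with Rattus norvegicus as the target (a lower number here means a stronger inhibitor, a higher number a weaker inhibitor), compound 3 gives the lowest of the three numbers; the steps leading to it are a 2.1-fold lower number from compound 1 to compound 3 (0.31 log units; beyond the scatter) and a 3.0-fold lower number from compound 2 to compound 3 (0.48 log units; beyond the scatter), both beyond the scatter, while a 1.5-fold higher number from compound 1 to compound 2 (0.17 log units; within the scatter) is within the scatter.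

The step to compound 4, `CC1(C)Oc2ccc(S(N)(=O)=O)cc2[C@@H](/N=C(\NC#N)Nc2ccc(Cl)cc2)[C@@H]1O`, leaves the aromatic-carbon position untouched and alters the phenylsulfamoyl group itself: hydrogen in place of phenyl on a sulfonamide nitrogen. Among the compounds with values here, no measured step works on this nitrogen; the two steps that bear on it only loosely are the exchanges at the aromatic carbon that led to compound 3, and both were modest. Removing the phenyl from the sulfonamide nitrogen is therefore untested ground, and the most that can be said is that compound 4 should stay within the spread of the three measured compounds.

Compound 4 is expected to give about 6000 nM, with a range from 2000 nM to 20000 nM. This estimate means a step of a 1.8-fold higher number from compound 3 to compound 4 (0.26 log units; within the scatter), expected to be a mild weakening at most.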

Compound 4, half-maximal inhibitory concentration: 41300 nM
The estimate for compound 4 lay 6.9-fold (0.84 log units) below the measured number, outside the stated range (above it).
By their numbers in this assay, from the lowest: compound 3; then compounds 1 and 2 (each within the scatter of the next); then compound 4.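

In this assay the phenyl on the sulfonamide nitrogen accounts for much of the standing of compound 3 (a 13-fold higher number from compound 3 to compound 4 (1.10 log units; beyond the scatter)), so the sulfonyl link alone does not deliver the lowest number in the set. Bare sulfamoyl also falls behind both benzyl and benzylcarbonyl (a 4.1-fold higher number from compound 2 to compound 4 (0.62 log units; beyond the scatter); a 6.1-fold higher number from compound 1 to compound 4 (0.78 log units; beyond the scatter)), whereas phenylsulfamoyl stood ahead of them, so the order among these substituents on the aromatic carbon turns on what sits on that nitrogen. Nothing available gives a reason for this loss.

Still open, going by these compounds, is whether the gain needs an aromatic ring at all or whether any carbon group on the nitrogen would serve, a question that a methyl or a benzyl there would separate from the phenyl result. Also open, on these data alone, is how far the phenyl itself can be changed and whether the remaining nitrogen hydrogen counts, which a chloro or methoxy on the phenyl ring and a sulfonamide nitrogen bearing both phenyl and methyl would address.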